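Acetyl in Place of Benzyl on Compound 3

The source may report more compounds than this note shows. Statements on the series, on what has been measured and on what is new or still open speak of the compounds shown alone.

Among the measured compounds shown here, in a functional assay on SK-MEL-5 cells (Homo sapiens) for cytotoxicity (on this read-out lower numbers stand for an effect already at smaller amounts and higher numbers for an effect only at larger amounts of compound), compound 3 `COc1ccc(/C=C\c2cc(OC)c(OCc3ccccc3)c(OC)c2)cc1` gives 6.1 uM, the only true number among the three values shown. Compound 1 `COC(=O)C(Cc1cc(OC)c(OC)c(OC)c1)c1ccc(OC)cc1` reaches only a limit of the assay in this assay, namely > 25 uM. Compound 2 `CCCOc1ccc(/C=C/c2cc(OC)c(OC)c(OC)c2)cc1` likewise gives only a limit, > 25 uM. Thus the limit of > 25 uM in this assay, at which 2 of the 3 values shown sit, marks where two of the three compounds sit, and compound 3 stands apart as the one with a measured concentration. Compound 4 `COc1ccc(/C=C\c2cc(OC)c(OC(C)=O)c(OC)c2)cc1` has not yet been tested in this assay. It differs from compound 3 in a single place: acetyl in place of benzyl on an oxygen on an aromatic ring. For the measured compounds named here, no step between two measured compounds is available here, so the size of the change in this assay can only be anticipated. The account expects a modest loss of effect from compound 3 to compound 4, estimated as a 1.6-fold higher number from compound 3 to compound 4 (0.21 log units; within the scatter), small enough that the two could also fall within ordinary variation. Compound 4 is therefore expected to give 10 uM, in a range from 3 uM to 30 uM.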

Compound 4, concentration for half-maximal effect: 0.6 uM
The estimate for compound 4 lay 17-fold (1.22 log units) above the measured number; measured number outside the range, below it.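

In this assay, what the oxygen on the aromatic ring carries turns out to matter a great deal: benzyloxy to acetoxy gives a 10-fold lower number from compound 3 to compound 4 (1.01 log units; beyond the scatter). The ring of benzyl is therefore not needed for the effect at this place, and the acetyl group, with no ring and with a hydrogen-bond acceptor, gives an effect at smaller amounts of compound. Nothing measured here gives a cause for this step.

The compounds shown leave open whether the acetyl group itself matters or whether removing benzyl is enough, a question that a free hydroxyl, a methoxy group or a longer acyl chain such as butyryl on this oxygen would address. Also open, going by these compounds, is whether the same exchange would have a similar effect on a core other than that of compound 3.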